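Picolinamide Variant of a Thiazole Carboxamide Antiproliferative Series

The source may hold more compounds than are shown below. What is called first, only, known or untested is meant among the compounds shown, and "the series" means these compounds.

Two close analogues share a thiazole carboxamide core and differ only at the far end of the benzamide. Compound 1 `CN1CCN(c2ccc(Nc3nc(-c4cccc(NC(=O)c5ccc(C(F)(F)F)cc5)c4)sc3C(N)=O)cc2)CC1` carries a trifluoromethyl on the benzamide ring and gives 1580 nM in a functional assay on Ramos cells (Homo sapiens) for antiproliferative activity, read by CCK-8 assay, with a stated time of 72 h; a lower number here means a stronger inhibitor, a higher number a weaker inhibitor. Compound 2 `CN1CCN(c2ccc(Nc3nc(-c4cccc(NC(=O)c5ccccc5)c4)sc3C(N)=O)cc2)CC1` lacks that group and gives 1760 nM in this assay; its number is the higher of the two, but the step of a 1.1-fold higher number from compound 1 to compound 2 (0.05 log units; within the scatter) does not rise above the scatter, so the two compounds cannot be ordered.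

Compound 3 `CN1CCN(c2ccc(Nc3nc(-c4cccc(NC(=O)c5ccc(C(F)(F)F)cn5)c4)sc3C(N)=O)cc2)CC1` is the next step from compound 2. The change is 5-(trifluoromethyl)pyridin-2-yl in place of phenyl on a carbonyl carbon. Part of this change, the return of a trifluoromethyl, is covered by the step from compound 1 to compound 2, which was flat. Among the compounds with values here, the exchange of a ring carbon for a ring nitrogen, with its one hydrogen-bond acceptor, has no precedent among the measured compounds. On this basis the expected step of a 1.2-fold lower number from compound 2 to compound 3 (0.07 log units; within the scatter) in this assay is small, with no clear direction beyond the scatter. Compound 3 is therefore estimated at 1500 nM in this assay, with a range from 600 nM to 3800 nM.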

Compound 3, half-maximal inhibitory concentration: 19800 nM
Beside the measured number, compound 3's estimate is 13-fold (1.12 log units) below it, and the stated range ends below it.
By their numbers in this assay, from the lowest: compounds 1 and 2 (each within the scatter of the next); then compound 3.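

The ring on the carbonyl carbon is less forgiving in this assay than the earlier pair suggested: removing the trifluoromethyl gave only a 1.1-fold higher number from compound 1 to compound 2 (0.05 log units; within the scatter) and left activity unresolved, yet the new ring brings an 11-fold higher number from compound 2 to compound 3 (1.05 log units; beyond the scatter) and so a clear loss. The closest comparison is a 13-fold higher number from compound 1 to compound 3 (1.10 log units; beyond the scatter) for 5-(trifluoromethyl)pyridin-2-yl in place of 4-(trifluoromethyl)phenyl, where the trifluoromethyl is present on both sides and the large step goes with the change to a ring with one hetero atom and one hydrogen-bond acceptor. Nothing measured here explains why this change is so costly.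

The compounds shown leave open whether the ring nitrogen alone carries this loss or whether it arises only together with the trifluoromethyl, a question that an unsubstituted pyridin-2-yl ring on the same carbonyl carbon would address. They also leave open how a pyridin-3-yl ring, or an amine or a carboxylic acid on the ring in place of the trifluoromethyl, would read in this assay and whether any such group would restore activity.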